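The source may report more compounds than this note shows. Statements on the series, on what has been measured and on what is new or still open speak of the compounds shown alone.

In a functional assay for inhibition, with Homo sapiens as the target (on this read-out higher numbers stand for weaker binding and lower numbers for tighter binding), compound 3 (`O=C(O)CC/C=C\CC1COC(c2cccnc2)OC1c1cccnc1`) gives 759 nM, compound 1 (`O=C(O)CC/C=C\CC1COC(c2ccccc2Cl)OC1c1cccnc1`) gives 759 nM and compound 2 (`O=C(O)CC/C=C\CC1COC(c2ccc([N+](=O)[O-])cc2)OC1c1cccnc1`) gives 933 nM, so all three sit within the scatter of one another. Compound 4 (`O=C(O)CC/C=C\CC1COC(c2cccs2)OC1c1cccnc1`) differs from compound 3 by thiophen-2-yl in place of pyridin-3-yl on a saturated ring carbon, with thiophen-2-yl in place of pyridin-3-yl on a saturated ring carbon. Three measured steps at this place bear on it: no change at the digits printed from compound 1 to compound 3 (within the scatter), a 1.2-fold lower number from compound 2 to compound 3 (0.09 log units; within the scatter) and a 1.2-fold higher number from compound 1 to compound 2 (0.09 log units; within the scatter), all within the scatter. None of them involves thiophen-2-yl, so the evidence is indirect. No step beyond the scatter is expected in this assay. The estimated step is a 1.1-fold higher number from compound 3 to compound 4 (0.02 log units; within the scatter). For compound 4 the expected value is 800 nM, with an estimated range of 450 nM to 1400 nM.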

Compound 4, dissociation constant: 1000 nM
Compound 4: middle estimate off by 1.3-fold (0.10 log units), on the low side, and the stated range covers the measured number.
By their numbers in this assay, from the lowest: compounds 1, 3, 2 and 4 (each within the scatter of the next).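

Thiophen-2-yl is the only five-membered aromatic ring among the compounds shown on this saturated ring carbon between two ring oxygen atoms, and it carries sulfur as its hetero atom, yet in this assay the steps to it are a 1.3-fold higher number from compound 3 to compound 4 (0.12 log units; within the scatter) and a 1.1-fold higher number from compound 2 to compound 4 (0.03 log units; within the scatter) and a 1.3-fold higher number from compound 1 to compound 4 (0.12 log units; within the scatter) and so all stay within the scatter. Across these four compounds, neither ring size nor the hetero atom separates the read-outs, and no compound goes against this. No measurement at hand gives a reason for this flat result.

From the compounds shown here alone, whether an aliphatic amine, a carboxylic acid or a saturated cyclohexyl ring on this carbon would step beyond the scatter stays open.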